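Swapping Back the Group on the Aromatic Nitrogen

The source may hold more compounds than are shown below. What is called first, only, known or untested is meant among the compounds shown, and "the series" means these compounds.

Compound 2 `CCOC(=O)C1=Cc2ccccc2OC1(OCc1cn(-c2ccc(F)c([N+](=O)[O-])c2)nn1)C(F)(F)F` carries the only number shown: in a functional assay on DU-145 cells (Homo sapiens) for inhibition, read by MTT assay, with a stated time of 24 h (on this read-out higher numbers stand for weaker inhibition and lower numbers for stronger inhibition), compound 2 gives 13200 nM. Compound 1 `CCOC(=O)C1=Cc2ccccc2OC1(OCc1cn(CC(=O)Nc2ccc(C)cc2)nn1)C(F)(F)F` gives > 150000 nM in this assay, which is a limit of the assay rather than a number. Compound 3 `CCOC(=O)C1=Cc2ccccc2OC1(OCc1cn(CC(=O)Nc2ccc(OC)cc2)nn1)C(F)(F)F` differs from compound 2 by ((4-methoxyphenyl)carbamoyl)methyl in place of 4-fluoro-3-nitrophenyl on an aromatic nitrogen. Among the compounds with values here, the single measured step bears on this change in reverse: an at least 11-fold lower number from compound 1 to compound 2 (1.05 log units; beyond the scatter). Running that step backwards, a large rise in the number is expected, namely an 11-fold higher number from compound 2 to compound 3 (1.06 log units; beyond the scatter). Compound 3 is therefore expected to give about 150000 nM, within a range from 30000 nM to 500000 nM, and may again reach only a limit.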

Compound 3, half-maximal inhibitory concentration: 32700 nM
Beside the measured number, compound 3's estimate is 4.6-fold (0.66 log units) above it; low and high end bracket the measured number.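

The ((4-methoxyphenyl)carbamoyl)methyl group on the aromatic nitrogen costs less than compound 1 suggested: the swap gives a 2.5-fold higher number from compound 2 to compound 3 (0.39 log units; beyond the scatter). So this position can carry this chain and still give a measurable number, and the group on an aromatic carbon matters too, with methoxy in place of methyl giving an at least 4.5-fold lower number from compound 1 to compound 3 (0.66 log units; beyond the scatter). That step is only a bound, since it starts from a limit: the limit of > 150000 nM in this assay, at which 1 of the 3 values shown sits.

Still open, from the compounds shown here alone, is whether a hydroxyl or a dimethylamino group in place of that methoxy would lower the number further. How a longer chain on the aromatic nitrogen would read is open as well.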